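Fluoro for hydrogen on two related cores

A few compounds are considered here, and "the series" means these few. Any claim that something is new, unique, unknown or untested is made for them only; others in the source may bear on it.

Measured so far in a functional assay on PC-3 cells (Homo sapiens) for cytotoxicity, read by WST assay, with a stated time of 24 h; a lower number here means a stronger inhibitor, a higher number a weaker inhibitor:
Compound 1 `COc1ccc2c(/C=C(\C#N)C(=O)c3c[nH]c4cc(F)ccc34)c[nH]c2c1`: compound 1 gives > 50000 nM, which is a limit of the assay and not a number.
Compound 2 `COc1ccc2[nH]cc(/C=C(\C#N)C(=O)c3c[nH]c4ccccc34)c2c1`: compound 2 gives 33200 nM.
Compound 3 `COc1ccc2c(/C=C(\C#N)C(=O)c3c[nH]c4ccccc34)c[nH]c2c1`: compound 3 gives 33300 nM.

Compound 2 and compound 3 hold the same atoms joined differently; the difference between the two cores is not broken down here. Their two values lie within the usual scatter of each other, so no order between them is claimed.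

Compound 1 arises from compound 3 by fluoro in place of hydrogen on an aromatic carbon. The measured step is an at least 1.5-fold higher number from compound 3 to compound 1 (0.17 log units; that floor lies within the scatter). Since the value of compound 1 is a limit, only the floor of that step is known, as recorded in the limit of > 50000 nM in this assay, at which 1 of the 3 values shown sits.

Compound 4 `COc1ccc2[nH]cc(/C=C(\C#N)C(=O)c3c[nH]c4cc(F)ccc34)c2c1` is still to be measured in this assay. It arises from compound 2 by fluoro in place of hydrogen on an aromatic carbon. The two place descriptions read the same word for word, so this is the same change that leads from compound 3 to compound 1, and it occurs twice among the compounds shown.

Resting on an at least 1.5-fold higher number from compound 3 to compound 1 (0.17 log units; that floor lies within the scatter), the step expected here is a 1.8-fold higher number from compound 2 to compound 4 (0.26 log units; within the scatter). Compound 4 is therefore expected near 60000 nM. The plausible range for compound 4 is estimated to run from 33000 nM to 150000 nM. As compound 1 returned only a limit, compound 4 may well do the same.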

Compound 4, half-maximal inhibitory concentration: > 50000 nM
Compound 4 was reported as a limit; the forecaster's own chance of this, stated with the estimate: 70%; the middle value lies beyond the limit too.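

In this assay, fluoro in place of hydrogen on an aromatic carbon gives an at least 1.5-fold higher number from compound 2 to compound 4 (0.17 log units; that floor lies within the scatter). Set beside the earlier case, the change points the same way on both cores only as far as the two floors can show, and a shared direction is all that can be carried from one core to the other: the same change on two cores in this assay, an at least 1.5-fold higher number (0.17 log units; that floor lies within the scatter) from compound 3 to compound 1 and an at least 1.5-fold higher number (0.17 log units; that floor lies within the scatter) from compound 2 to compound 4; the limit leaves it open whether they differ Neither step has a known size, and neither floor lies beyond the scatter, so these data do not establish that fluoro weakens either core, nor that it acts to the same extent on both: the limit of > 50000 nM in this assay, at which 2 of the 4 values shown sit.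

Still open, from the compounds shown here alone, is whether either fluoro compound truly differs from its parent by more than the scatter, which only a value in place of a limit could settle. Also open, going by these compounds, is how a different group in that aromatic place, such as an amine, a carboxylic acid or a longer chain, would read against compound 2 at 33200 nM in this assay, and whether any such group would give a lower number on either core.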